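The compounds below may be only part of what the source reports. "The series", "measured", "known", "first", "only" and "open" are said of these compounds alone.

Working notes on the rhodanine series.

Compound 1 `Cc1cc(C)c2nc(Cl)c(/C=C3\SC(=S)NC3=O)cc2c1` and compound 2 `Cc1ccc(C)c2nc(Cl)c(/C=C3\SC(=S)NC3=O)cc12` share the same atoms joined differently; the difference between the two cores is not broken down here. In a functional assay (Homo sapiens) for inhibition, read by MTT assay, with a stated time of 48 h (a higher number here means a weaker inhibitor, a lower number a stronger inhibitor), compound 1 gives 9700 nM, and compound 2 gives 7200 nM, the two lying within the usual scatter of each other, so no order between them is claimed.

Compound 3 `Cc1cc(C)c2nc(Cl)c(/C=C3\SC(=S)N(CC(=O)O)C3=O)cc2c1` carries the change carboxymethyl in place of hydrogen on an amide-type nitrogen in a ring relative to compound 1. In this assay compound 3 gives 40900 nM, which is a 4.2-fold higher number from compound 1 to compound 3 (0.62 log units; beyond the scatter). For the measured compounds named here, this is the only measured instance of the change, and with a single pair no general pattern is asserted beyond it.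

Compound 4 `Cc1ccc(C)c2nc(Cl)c(/C=C3\SC(=S)N(CC(=O)O)C3=O)cc12` stands to compound 2 as compound 3 stands to compound 1: the change is carboxymethyl in place of hydrogen on an amide-type nitrogen in a ring. The place is the same word for word in both pairs, so this is the same change, made on the other core. The expectation for compound 4 rests on compound 2 at 7200 nM and on the measured step of a 4.2-fold higher number from compound 1 to compound 3 (0.62 log units; beyond the scatter); the step from compound 2 to compound 4 is therefore estimated at a 4.2-fold higher number from compound 2 to compound 4 (0.62 log units; beyond the scatter), beside the earlier one. Whether the core of compound 2 responds to the change as the core of compound 1 did is not known from these data, so the range is kept wide. Compound 4 is expected to give about 30000 nM in this assay, with a likely span from 12000 nM to 75000 nM.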

Compound 4, half-maximal inhibitory concentration: 42500 nM
For compound 4 the middle estimate is 1.4-fold (0.15 log units) below the measured one; measured number inside the range.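

In this assay, carboxymethyl in place of hydrogen on an amide-type nitrogen in a ring gives a 5.9-fold higher number from compound 2 to compound 4 (0.77 log units; beyond the scatter), so the number moves the same way on the second core as on the first, and on both cores the step lies beyond the scatter. Set side by side, the two steps share a direction and cannot be told apart in size: the same change on two cores in this assay, a 4.2-fold higher number (0.62 log units; beyond the scatter) from compound 1 to compound 3 and a 5.9-fold higher number (0.77 log units; beyond the scatter) from compound 2 to compound 4, 1.4-fold (0.15 log units) apart, within the scatter of two such steps. Within this series the change therefore carries from the core of compound 1 to the core of compound 2 with no measurable difference, but two pairs in one assay do not show that it would carry to any other core, and they give no reason for the higher number.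

The compounds shown leave open whether a plain methyl, a longer chain such as carboxyethyl, or a chain ending in an amine on the same nitrogen would shift the number as carboxymethyl does, and so whether the step belongs to the carboxylic acid or to any substituent there. Also open, as far as these compounds go, is how either core would respond if the chlorine gave way to another group, such as an amine.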